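Benzylsulfanyl on a Nucleoside Core Reaching the Assay Limit

The source may report more compounds than this note shows. Statements on the series, on what has been measured and on what is new or still open speak of the compounds shown alone.

Measured so far:
Compound 1 `CSc1nc2cnsc2[nH]1`: 15000 nM
Compound 2 `Cc1nsc2c1ncn2[C@H]1C[C@H](O)[C@@H](CO)O1`: > 100000 nM
Compound 3 `CSc1nc2cnsc2n1[C@H]1C[C@H](O)[C@@H](CO)O1`: > 100000 nM

Of the compounds shown here, three have been tested in a functional assay on KB cells (Homo sapiens) for antiproliferative activity; on this read-out lower numbers stand for stronger inhibition and higher numbers for weaker inhibition. Compound 1 gives a numeric value of 15000 nM. Compound 2, which carries a methyl group and the sugar, reaches only the limit of the assay, > 100000 nM, and so no number is known for it. Compound 3 likewise reaches only the limit, > 100000 nM. Thus compound 2 stands at the upper edge of what this assay reports, as does compound 3, so that the limit of > 100000 nM in this assay, at which 2 of the 3 values shown sit, sets the frame for anything drawn from it. No pair of these compounds differs in a single place, and no measured step can be stated.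

The next compound is compound 4 `Cc1nsc2c1nc(SCc1ccccc1)n2[C@H]1C[C@H](O)[C@@H](CO)O1`. It differs from compound 2 by benzylsulfanyl in place of hydrogen on an aromatic carbon. With compound 2 itself at a limit, there is no measured starting number from which a step could be read, and compound 3 shows that a sulfanyl substituent at this position on a sugar-bearing core also sits at the limit. Compound 4 is therefore expected to show a step from compound 2 of about an at least 1.2-fold lower number from compound 2 to compound 4 (0.09 log units; that floor lies within the scatter), that is, none beyond the scatter in this assay. Compound 4 is estimated at 80000 nM, in a range from 20000 nM to 300000 nM, with a fair chance that only a limit is reported.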

Compound 4, half-maximal inhibitory concentration: > 100000 nM
Compound 4: only a limit was reported; the forecaster's own chance of this, stated with the estimate: 55%; at least 1.2-fold (0.09 log units) between middle value and limit.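

In this assay compound 4 gives > 100000 nM as a limit and not a number. Going by these compounds alone, no step from compound 2 to compound 4 can be read, because both compounds stand at a limit: the limit of > 100000 nM in this assay, at which 3 of the 4 values shown sit. The compounds shown leave open whether benzylsulfanyl in place of hydrogen on an aromatic carbon alters the activity of compound 2 at all.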